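Replacing 2,4-dichlorophenyl in compound 2

The source may report more compounds than this note shows. Statements on the series, on what has been measured and on what is new or still open speak of the compounds shown alone.

Going by the values given here, in a functional assay on SK-OV-3 cells (Homo sapiens) (a lower number here means a stronger inhibitor of growth, a higher number a weaker inhibitor of growth), compound 2 `O=S(=O)(/C=C/c1ccc(Cl)cc1Cl)Cc1ccc(Nc2ncnc3ccc(Br)cc23)cc1` gives 1000 nM as the lower of the two numbers so far, while compound 1 `O=S(=O)(/C=C/c1ccc(C(F)(F)F)cc1F)Cc1ccc(Nc2ncnc3ccccc23)cc1` gives 39000 nM and the gap lies beyond the scatter. Compound 3 `O=S(=O)(/C=C/c1ccc(C(F)(F)F)cc1F)Cc1ccc(Nc2ncnc3ccc(Br)cc23)cc1` keeps the core of compound 2. The change 2-fluoro-4-(trifluoromethyl)phenyl in place of 2,4-dichlorophenyl on a double-bonded chain carbon bound to a double-bonded chain carbon puts 2-fluoro-4-(trifluoromethyl)phenyl in place of 2,4-dichlorophenyl on a double-bonded chain carbon bound to a double-bonded chain carbon. Among the compounds with values here, no step in one place has been measured, so this change has no direct precedent. A modest move towards weaker inhibition is expected in this assay with a 2.5-fold higher number from compound 2 to compound 3 (0.40 log units; beyond the scatter) as the estimated step. Compound 3 is estimated at 2500 nM with a range from 800 nM to 12000 nM as expected bounds.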

Compound 3, concentration for 50% growth inhibition: 5000 nM
Estimate against measurement, compound 3: 2.0-fold (0.30 log units) below, within the range that was stated.
By their numbers in this assay, from the lowest: compound 2; then compound 3; then compound 1.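

In this assay, 2-fluoro-4-(trifluoromethyl)phenyl in place of 2,4-dichlorophenyl on a double-bonded chain carbon gives a 5.0-fold higher number from compound 2 to compound 3 (0.70 log units; beyond the scatter), so with bromo held constant, this position is sensitive to the change of aryl group. Bromo in place of hydrogen on an aromatic carbon gives a 7.8-fold lower number from compound 1 to compound 3 (0.89 log units; beyond the scatter), a gain in growth inhibition with 2-fluoro-4-(trifluoromethyl)phenyl held constant. No supporting data are available to explain either step.

Still open, going by these compounds, is whether the bromo step has a similar size with 2,4-dichlorophenyl in place. Also open, on these data alone, is how an amine or a carboxylic acid would fare in place of the 2-fluoro-4-(trifluoromethyl)phenyl substituents.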